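The source may hold more compounds than are shown below. What is called first, only, known or untested is meant among the compounds shown, and "the series" means these compounds.

Measured so far:
compound 1 `CCOC(=O)c1cccc(NC(=O)N[C@H](C)c2ccccc2)c1`: 94%
compound 2 `COc1cccc(NC(=O)N[C@H](C)c2ccccc2)c1`: 92%

In an ADME assay on the whole organism with Oryza sativa as the target, tested at 1 uM (a higher number here means a weaker effect of the compound at the concentration tested, a lower number a stronger effect), compound 1 gives 94% and compound 2 gives 92%. Compound 2 holds the lowest of the two numbers shown; compound 1 is its nearest neighbour, and the step of a number 2 percentage points lower from compound 1 to compound 2 (within the scatter) does not separate the two. Compound 3 `CC(=O)c1cccc(NC(=O)N[C@H](C)c2ccccc2)c1` has not yet been measured in this assay. Its change from compound 2 is as follows: acetyl in place of methoxy on an aromatic carbon. Among the compounds with values here, the one measured step that bears on this exchange is the one from compound 1 to compound 2, which also swaps the substituent at the same aromatic carbon and stays within the scatter. A further exchange of that substituent, methoxy for acetyl, is therefore expected to move the read-out in this assay by no more than the scatter, a number 1 percentage points higher from compound 2 to compound 3 (within the scatter). Compound 3 is estimated at 93%, with an expected range from 85% to 100%.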

Compound 3, a percentage reported as activity, at one concentration (the size of the read-out at that concentration, not a potency): 88%
The estimate for compound 3 lay 5 percentage points above the measured number, and the stated range covers the measured number.
By their numbers in this assay, from the lowest: compounds 3, 2 and 1 (each within the scatter of the next).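

In this assay, acetyl in place of methoxy on this aromatic carbon, meta to a large group, gives a number 4 percentage points lower from compound 2 to compound 3 (within the scatter), so a third substituent at this position also stays inside the scatter. Methyl in place of ethoxy on a carbonyl carbon gives a number 6 percentage points lower from compound 1 to compound 3 (within the scatter); this is the first exchange shown that keeps the carbonyl and alters only what it carries, and it does not separate the two compounds either. Nothing available explains these numbers or the absence of a separation between them.

On these data alone, whether any group at this aromatic carbon can produce a step beyond the scatter remains open, for example an amine, a carboxylic acid or a longer chain. As far as these compounds go, whether acetyl or methoxy would behave the same way at another carbon of this ring also remains open.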